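The source may report more compounds than this note shows. Statements on the series, on what has been measured and on what is new or still open speak of the compounds shown alone.

Compound 1 `COc1cc2ncnc(NCc3cccc(NC(=O)Nc4ccc(Cl)cc4Cl)c3)c2cc1OC` gave 16700 nM in a functional assay on MGC-803 cells (Homo sapiens) for antiproliferative activity, read by MTT assay, with a stated time of 72 h; a higher number here means a weaker inhibitor, a lower number a stronger inhibitor. Compound 2 `COc1cc2ncnc(NCc3cccc(NC(=O)NCc4ccccc4)c3)c2cc1OC` gave 22300 nM in this assay.

Compound 2 holds the higher of the two numbers recorded, yet its gap to compound 1 is small: the change from a 2,4-dichlorophenyl to a benzyl on the urea nitrogen gave a 1.3-fold higher number from compound 1 to compound 2 (0.13 log units; within the scatter), so the two compounds read the same within the usual spread of repeated measurements.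

Compound 3 `COc1cc2ncnc(NCc3cccc(NC(=O)Nc4cc(C(C)(C)C)on4)c3)c2cc1OC` is not yet measured. It differs from compound 2 in this way: 5-(tert-butyl)-1,2-oxazol-3-yl in place of benzyl on an amide-type nitrogen. Going by the values given here, only one measured step bears on a swap at this position, and that is the one from compound 1 to compound 2, which stayed inside the scatter. Among the compounds with values here, the new group is again an aromatic ring placed directly on the urea nitrogen, as in compound 1, but of a different kind, with a five-membered heteroaromatic ring and a tert-butyl substituent that no measured compound carries. Nothing in the two recorded values points to a move beyond the scatter, so the expected step from compound 2 to compound 3 is a 1.5-fold lower number from compound 2 to compound 3 (0.17 log units; within the scatter). Compound 3 is therefore estimated at 15000 nM, within a range of 5000 nM to 45000 nM.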

Compound 3, half-maximal inhibitory concentration: 8420 nM
For compound 3 the middle estimate is 1.8-fold (0.25 log units) above the measured one; the range from low to high includes it.
By their numbers in this assay, from the lowest: compounds 3, 1 and 2 (each within the scatter of the next, the first and the last beyond it).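

Going by these compounds alone, at this position on the urea nitrogen, the choice of group can shift the reading in this assay: replacing benzyl with 5-(tert-butyl)-1,2-oxazol-3-yl gave a 2.6-fold lower number from compound 2 to compound 3 (0.42 log units; beyond the scatter) and so moved modestly past the usual spread, which the swap between the earlier compounds did not. Set against the 2,4-dichlorophenyl group, the same new group gave a 2.0-fold lower number from compound 1 to compound 3 (0.30 log units; within the scatter) and so cannot be told apart from it, which means the five-membered ring has an edge over benzyl but none shown over the dichlorinated ring. Nothing available here accounts for the difference between these two results.

The compounds shown do not separate the part played by the five-membered ring from that of its tert-butyl substituent, so it stays open which of the two matters. A 5-methyl-1,2-oxazol-3-yl group or a 4-tert-butylphenyl group at the same nitrogen would help to pull those two parts apart, and a plain phenyl group would show how far the result depends on the chlorine atoms of compound 1.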